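From chloro to bromo on an aromatic carbon

This account rests on a few compounds, and the source may have more. Where it says the series, first, only, none or still open, it means among the compounds named here.

Compounds measured in a functional assay on A549 cells (Homo sapiens) for antiproliferative activity, read by MTT assay, with a stated time of 48 h; on this read-out lower numbers stand for stronger inhibition and higher numbers for weaker inhibition:
- compound 1 `Cc1ccc(C(=O)/C=C/c2cc(Br)cc(Br)c2Oc2c([N+](=O)[O-])cc(C(F)(F)F)cc2[N+](=O)[O-])cc1`: 10.1 ug/mL
- compound 2 `O=C(/C=C/c1cc(Br)cc(Br)c1Oc1c([N+](=O)[O-])cc(C(F)(F)F)cc1[N+](=O)[O-])c1ccc(F)cc1`: 120 ug/mL
- compound 3 `O=C(/C=C/c1cc(Br)cc(Br)c1Oc1c([N+](=O)[O-])cc(C(F)(F)F)cc1[N+](=O)[O-])c1ccc(Cl)cc1`: 19.4 ug/mL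

Compound 3 is not separated from the methyl analogue, the measured step being a 1.9-fold higher number from compound 1 to compound 3 (0.28 log units; within the scatter). It stands well clear of the fluoro analogue, with a 6.2-fold lower number from compound 2 to compound 3 (0.79 log units; beyond the scatter). Compound 4 `O=C(/C=C/c1cc(Br)cc(Br)c1Oc1c([N+](=O)[O-])cc(C(F)(F)F)cc1[N+](=O)[O-])c1ccc(Br)cc1` carries bromo in place of chloro on an aromatic carbon, para to a large group: bromo in place of chloro on an aromatic carbon. The largest relevant step is a 12-fold higher number from compound 1 to compound 2 (1.07 log units; beyond the scatter), so compound 2 alone stands apart, at 120 ug/mL. With chloro and methyl inseparable, no step beyond the scatter is expected in this assay for this exchange. Compound 4 is estimated at 16 ug/mL, with an expected range of 6 ug/mL to 45 ug/mL. The estimated change is a 1.2-fold lower number from compound 3 to compound 4 (0.08 log units; within the scatter).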

Compound 4, half-maximal inhibitory concentration: 16.8 ug/mL
Compound 4: the middle estimate sits 1.1-fold (0.02 log units) below what was measured; measured number inside the range.
By their numbers in this assay, from the lowest: compounds 1, 4 and 3 (each within the scatter of the next); then compound 2.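

In this assay, the 4-bromophenyl of compound 4 cannot be separated from the 4-chlorophenyl (a 1.2-fold lower number from compound 3 to compound 4 (0.06 log units; within the scatter)) or from the methyl analogue (a 1.7-fold higher number from compound 1 to compound 4 (0.22 log units; within the scatter)). The gap to the fluoro analogue remains (a 7.1-fold lower number from compound 2 to compound 4 (0.85 log units; beyond the scatter)), so bromo joins chloro and methyl at this position, and among these four compounds fluoro alone stands apart. Nothing given here accounts for that separation. On these data alone, whether an amine or a methoxy group at this position would sit with chloro, bromo and methyl or with fluoro remains open. So does whether fluoro stands apart on other cell lines.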